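Methyl in place of chloro: expectation for compound 3

The source may report more compounds than this note shows. Statements on the series, on what has been measured and on what is new or still open speak of the compounds shown alone.

Measured so far:
compound 1 `Cc1n[nH]c2ccc(-c3nc4cnc(N5CCN(C)CC5)cn4c3Nc3ccccc3F)cc12`: 0%
compound 2 `Cc1n[nH]c2ccc(-c3nc4cnc(N5CCN(C)CC5)cn4c3Nc3ccc(Br)cc3Cl)cc12`: 70.5%

Within the data shown here, in a functional assay on MV4-11 cells (Homo sapiens) for inhibition, with a stated time of 120 h, tested at 10 uM (a lower number here means less inhibition, a higher number more inhibition at the concentration tested (going by the name of the read-out)), compound 2 gives the highest of the two numbers, the only other being compound 1 with 0%, and the sole measured step is a number 70.5 percentage points higher from compound 1 to compound 2 (beyond the scatter). Compound 3 `Cc1cc(Br)ccc1Nc1c(-c2ccc3[nH]nc(C)c3c2)nc2cnc(N3CCN(C)CC3)cn12` differs from compound 2 by methyl in place of chloro on an aromatic carbon. Among the measured compounds shown here, that step rearranges the whole substituted ring and so bears on this swap only loosely; no measured pair exchanges one group for another at a single carbon. A small step, a number 10.5 percentage points lower from compound 2 to compound 3 (beyond the scatter), is therefore expected, possibly within the scatter. Compound 3 is estimated at 60%, range 30% to 85%.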

Compound 3, a percentage reported as inhibition, at one concentration (the size of the read-out at that concentration, not a potency): 59.4%
The estimate for compound 3 lay 0.6 percentage points above the measured number; measured number inside the range.
By their numbers in this assay, from the lowest: compound 1; then compound 3; then compound 2.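

In this assay, methyl in place of chloro on this aromatic carbon, ortho to a large group, gives a number 11.1 percentage points lower from compound 2 to compound 3 (beyond the scatter), so the inhibition in this assay is lower with methyl than with chloro here. The 4-bromo-2-methylphenyl group retains most of the gain over 2-fluorophenyl, with a number 59.4 percentage points higher from compound 1 to compound 3 (beyond the scatter). Nothing available explains the loss on moving from chloro to methyl.

From the compounds shown here alone, how much of the gain belongs to the bromo group alone remains open. So does the outcome with an amine or a methoxy group on this carbon.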